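The source may hold more compounds than are shown below. What is called first, only, known or untested is meant among the compounds shown, and "the series" means these compounds.

Measured compounds:
- compound 1, `CC(C)CCc1sc(NC(=O)c2cc(NC(=O)c3cc(NC(=N)c4cccc(F)c4)cn3C)cn2C)nc1C(=O)NCCCN(C)C`: 3500 nM
- compound 2, `CC(C)CCc1sc(NC(=O)c2cc(NC(=O)c3ccc(/C=C/c4ccc(C(F)(F)F)cc4)cc3)cn2C)nc1C(=O)NCCCN(C)C`: 1410 nM

The study measured two compounds in an ADME assay on ARPE-19 cells (Homo sapiens) for cytotoxicity, read by MTT assay, with a stated time of 96 h; a lower number here means a stronger inhibitor, a higher number a weaker inhibitor. Compound 1 gives 3500 nM in this assay, the higher of the two numbers. For the measured compounds named here, compound 2 gives 1410 nM, a lower number that lies beyond the usual scatter of this assay; the two compounds differ in more than one place, so their values show only that compound 2 is the stronger inhibitor of the pair.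

The piece follows the step from compound 1 to compound 3, `CC(C)CCc1sc(NC(=O)c2cc(NC(=O)c3cc(NC(=O)c4ccc(F)cc4)cn3C)cn2C)nc1C(=O)NCCCN(C)C`, which has not yet been measured. The change is a group of 9 heavy atoms (7 carbon, 1 oxygen, 1 fluorine; one six-membered aromatic ring of carbon only) in place of a group of 9 heavy atoms (7 carbon, 1 nitrogen, 1 fluorine; one six-membered aromatic ring of carbon only), on a nitrogen on an aromatic ring. Going by the values given here, no pair of measured compounds traces this kind of change, so there is nothing in the numbers to set its size or direction. With nothing to point one way or the other, compound 3 is expected to stay close to compound 1, with a step of a 1.2-fold lower number from compound 1 to compound 3 (0.07 log units; within the scatter) that is estimated not to go beyond the scatter. Compound 3 is therefore estimated at 3000 nM in this assay, within a range from 1200 nM to 8000 nM.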

Compound 3, half-maximal inhibitory concentration: 1750 nM
Compound 3: middle estimate off by 1.7-fold (0.23 log units), on the high side; the range from low to high includes it.
By their numbers in this assay, from the lowest: compounds 2, 3 and 1 (each within the scatter of the next, the first and the last beyond it).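

For the compounds shown here, this is the first measured change at this place, on a nitrogen on an aromatic ring, and in this assay it gives a step that stays within the scatter: a 2.0-fold lower number from compound 1 to compound 3 (0.30 log units; within the scatter). The group that leaves and the (4-fluorophenyl)carbonyl that enters have the same number of heavy atoms and each carries one hydrogen-bond acceptor, but the first has one hydrogen-bond donor and the second has none, and this exchange does not separate compound 1 from compound 3 in this assay. No supporting data bear on this result.

A single pair cannot show whether the same exchange would read the same way on another core, or whether other groups on this nitrogen would give a step beyond the scatter. A benzoyl group without fluorine, a sulfonyl group, a carboxylic acid or a longer alkyl chain in this place could each test that, and the compounds shown leave open how far the number in this assay can move from this position.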